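Moving One Chlorine on the Dichlorophenyl Group

This account rests on a few compounds, and the source may have more. Where it says the series, first, only, none or still open, it means among the compounds named here.

In a functional assay on Daoy cells (Homo sapiens) for antiproliferative activity, read by trypan blue exclusion and crystal violet staining, with a stated time of 72 h (on this read-out lower numbers stand for stronger inhibition and higher numbers for weaker inhibition), compound 2 `CCCCC(=O)NC(c1ccc(Cl)c(Cl)c1)c1ccc2cccnc2c1O` gives 100 nM, level at the digits shown with compound 1 `CCCC(=O)NC(c1ccc(C)cc1)c1cc(Cl)c2cccnc2c1O` at 100 nM; together these are the lowest of three numbers, and compound 3 `CCCC(=O)NC(c1ccccc1)c1cc(Cl)c2cccnc2c1O` at 110 nM sits within the scatter of both. Compound 4 `CCCCC(=O)NC(c1cc(Cl)cc(Cl)c1)c1ccc2cccnc2c1O` differs from compound 2 by 3,5-dichlorophenyl in place of 3,4-dichlorophenyl on a saturated chain carbon bound to an amide-type nitrogen and an aromatic carbon. Going by the values given here, no measured step bears directly on this change; the only single-point step, a 1.1-fold higher number from compound 1 to compound 3 (0.04 log units; within the scatter), swaps methyl for hydrogen on an aromatic carbon and stays within the scatter, which gives no sign that the aromatic substituents move the number. The step of a 1.1-fold higher number from compound 2 to compound 4 (0.04 log units; within the scatter) is therefore expected to stay within the scatter. Compound 4 is estimated at 110 nM, with a range from 50 nM to 250 nM.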

Compound 4, half-maximal inhibitory concentration: 140 nM
Estimate against measurement, compound 4: 1.3-fold (0.10 log units) below; low and high end bracket the measured number.
By their numbers in this assay, from the lowest: compounds 1, 2, 3 and 4 (each within the scatter of the next).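

In this assay, moving one chlorine gives a 1.4-fold higher number from compound 2 to compound 4 (0.15 log units; within the scatter), so at this position on the saturated chain carbon, 3,5-dichlorophenyl and 3,4-dichlorophenyl cannot be told apart. The earlier step, which swapped methyl for hydrogen on an aromatic carbon, said nothing about the placement of the two chlorines. No measurement to hand offers an explanation for this result.

The compounds shown leave open whether a methoxy group, an amine or a carboxylic acid on this phenyl ring would keep the number level. They also leave open what a single chlorine would do.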